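The source may report more compounds than this note shows. Statements on the series, on what has been measured and on what is new or still open speak of the compounds shown alone.

Working notes on the series. Of the compounds shown here, two have been measured in a functional assay on HeLa cells (Homo sapiens) for antiproliferative activity, read by MTT assay, with a stated time of 48 h; a higher number here means a weaker inhibitor, a lower number a stronger inhibitor. Compound 1 `COc1ccc2nc(Nc3ccnc(Nc4ccc(S(N)(=O)=O)cc4)n3)sc2c1` gives 1730 nM, and compound 2 `CS(=O)(=O)c1ccc(Nc2nccc(Nc3nc4ccc(Cl)cc4s3)n2)cc1` gives 1400 nM. Compound 2 stands at the lowest of the two numbers, but its nearest neighbour is compound 1, whose number is higher only within the usual scatter, so no order between the two can be claimed.

The next step leads from compound 2 to compound 3 `COc1ccc2nc(Nc3ccnc(Nc4ccc(S(C)(=O)=O)cc4)n3)sc2c1`. The change is methoxy in place of chloro on an aromatic carbon. Within the data shown here, no measured pair in the set differs in exactly this way, so the size of the step rests on what the two measured compounds show. Compound 1, which also carries a methoxy, sits within the scatter of compound 2 in this assay, and nothing in the data points to a large effect from the exchange of chloro for methoxy at that aromatic carbon.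

For compound 3 the expected result in this assay is 1500 nM, with a range of 700 nM to 3300 nM. This estimate means a step of a 1.1-fold higher number from compound 2 to compound 3 (0.03 log units; within the scatter), expected to lie within the scatter rather than beyond it.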

Compound 3, half-maximal inhibitory concentration: 4130 nM
Beside the measured number, compound 3's estimate is 2.8-fold (0.44 log units) below it; the measured number lies above the stated range.
By their numbers in this assay, from the lowest: compounds 2 and 1 (each within the scatter of the next); then compound 3.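

In this assay, among these compounds, methoxy in place of chloro on an aromatic carbon of the six-membered carbon-only ring of the fused system gives a 3.0-fold higher number from compound 2 to compound 3 (0.47 log units; beyond the scatter), the first single-place reading at this position, and it shows that the exchange is not neutral when methyl sits on the sulfonyl sulfur. With methoxy held constant, methyl in place of amino on a sulfonyl sulfur gives a 2.4-fold higher number from compound 1 to compound 3 (0.38 log units; beyond the scatter), so the group on that sulfur also shifts the number, and both steps are modest but beyond the scatter. The data shown offer no measurement that explains either step.

As far as these compounds go, whether methoxy in place of chloro gives a step of similar size with amino on the sulfonyl sulfur remains open, since each step has been read in only one setting. Also open, from the compounds shown here alone, is how an ethoxy group, a fluorine or an amine on the same aromatic carbon would compare with chloro and methoxy in this assay.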